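Replacing a Trifluoromethylphenyl Group on a Triazole Ring

The source may hold more compounds than are shown below. What is called first, only, known or untested is meant among the compounds shown, and "the series" means these compounds.

Of the compounds shown here, three sharing one core have been measured in an ADME assay on HEK293 cells (Homo sapiens) for cytotoxicity, read by sulforhodamine B assay, with a stated time of 48 h, tested at 10 uM; on this read-out lower numbers stand for less inhibition and higher numbers for more inhibition at the one concentration tested (going by the name of the read-out). Compound 1 `CCCCCCCc1cn(C(c2ccccc2)c2cc3cc(Br)ccc3nc2OC)nn1` gives 0.17%. Compound 2 `CCCCCCCCc1cn(C(c2ccccc2)c2cc3cc(Br)ccc3nc2OC)nn1` gives 14.6%, and compound 3 `COc1nc2ccc(Br)cc2cc1C(c1ccccc1)n1cc(-c2ccccc2C(F)(F)F)nn1` gives 14.3%. Compound 3 stands second highest of the three numbers: its nearest neighbour is compound 2, within the scatter, and its furthest is compound 1, beyond the scatter. The measured steps are a number 14.4 percentage points higher from compound 1 to compound 2 (beyond the scatter), a number 14.1 percentage points higher from compound 1 to compound 3 (beyond the scatter) and a number 0.3 percentage points lower from compound 2 to compound 3 (within the scatter).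

Compound 4 `COc1nc2ccc(Br)cc2cc1C(c1ccccc1)n1cc(-c2cccc(F)c2)nn1` differs from compound 3 at the same carbon of the five-membered ring: 3-fluorophenyl in place of 2-(trifluoromethyl)phenyl on an aromatic carbon. The steps that touch this carbon, from compound 1 to compound 3 and from compound 2 to compound 3, exchange a heptyl or an octyl chain for an aryl group, and they differ from each other only within the scatter. Going by the values given here, no measured step swaps one aryl group for another, so there is no direct precedent. Compound 4 is therefore expected to stay close to compound 3, with a step of a number 2.3 percentage points lower from compound 3 to compound 4 (within the scatter) in this assay, within the scatter. The estimate for compound 4 is 12%, with a range from 0% to 28%.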

Compound 4, a percentage reported as inhibition, at one concentration (the size of the read-out at that concentration, not a potency): 6.84%
For compound 4 the middle estimate is 5.2 percentage points above the measured one; the measured number falls inside the stated range.
By their numbers in this assay, from the lowest: compounds 1, 4, 3 and 2 (each within the scatter of the next, the first and the last beyond it).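

In this assay, going by these compounds alone, this is the first exchange of one aryl group for another on this carbon of the five-membered ring, and 3-fluorophenyl in place of 2-(trifluoromethyl)phenyl gives a number 7.5 percentage points lower from compound 3 to compound 4 (within the scatter) and so does not separate the two aryl groups. Set against the chains, a number 7.8 percentage points lower from compound 2 to compound 4 (within the scatter) and a number 6.7 percentage points higher from compound 1 to compound 4 (within the scatter) show that a 3-fluorophenyl group cannot be told apart from either octyl or heptyl here, even though those two chain compounds lie beyond the scatter of each other. No measurement at hand accounts for any of these steps.

Still open, as far as these compounds go, is whether a phenyl ring carrying an amine or a carboxylic acid on this carbon would give a step beyond the scatter from compound 4. A chain longer than octyl at the same carbon also remains an open case.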